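Amide substituent series: isobutyl amide, compound 3

The compounds below may be only part of what the source reports. "The series", "measured", "known", "first", "only" and "open" are said of these compounds alone.

Working notes on the amide side chain of the shared core. Compound 1 `CCCNC(=O)c1ccc2c(ccn2-c2ncc3c(n2)N(c2ccn(C)n2)C(CC)C(=O)N3C)c1` carries the propylcarbamoyl group; in an assay for inhibition of serine/threonine-protein kinase PLK3 (Homo sapiens), read by FRET and Z'-LYTE, with a stated time of 1 h (on this read-out lower numbers stand for stronger inhibition and higher numbers for weaker inhibition), compound 1 gives > 10000 nM, which is a limit of the assay and not a number. Compound 2 `CCNC(=O)c1ccc2c(ccn2-c2ncc3c(n2)N(c2ccn(C)n2)C(CC)C(=O)N3C)c1` carries the ethylcarbamoyl group. In this assay compound 2 gives > 10000 nM, again a limit rather than a number. The step from compound 1 to compound 2 therefore reads a step that the two limits leave unreadable from compound 1 to compound 2. Where compound 2 stands, then, is only at the limit of > 10000 nM in this assay, at which 2 of the 2 values shown sit, and nothing in the series sets it apart from compound 1.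

Compound 3 `CCC1C(=O)N(C)c2cnc(-n3ccc4cc(C(=O)NCC(C)C)ccc43)nc2N1c1ccn(C)n1` is the next step outward: isopropyl in place of methyl on a saturated chain carbon bound to an amide-type nitrogen. Among the measured compounds shown here, no measured step bears readably on it, since the one recorded step on this chain is unreadable between two limits. The expectation for compound 3 in this assay is accordingly a step that the limit leaves unreadable from compound 2 to compound 3, with the value most likely still at the limit. Compound 3 is estimated at 15000 nM, with a range from 4000 nM to 60000 nM.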

Compound 3, half-maximal inhibitory concentration: > 10000 nM
Compound 3: only a limit was reported; the forecaster's own chance of this, stated with the estimate: 80%; the middle value is on the limit's open side.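

No step among compound 1, compound 2 and compound 3 can be read, as all three stand at a limit of the assay and not at a number: the limit of > 10000 nM in this assay, at which 3 of the 3 values shown sit.

The compounds shown leave open whether any amide side chain on the shared core reads as a number in this assay, and how the ethylcarbamoyl, propylcarbamoyl and isobutylcarbamoyl groups would rank there.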